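Anilino-to-piperidinyl swap on a fused tetracyclic quinone core

The source may hold more compounds than are shown below. What is called first, only, known or untested is meant among the compounds shown, and "the series" means these compounds.

Measured in a functional assay on MGC-803 cells (Homo sapiens) for inhibition, read by sulforhodamine B assay; on this read-out lower numbers stand for stronger inhibition and higher numbers for weaker inhibition:
compound 1 `CCc1ccc(NC2=CC(=O)c3nc4n(c3C2=O)[C@H]2OC[C@@H](O)[C@H]2OC4)cc1`: 1290 nM
compound 2 `O=C1C=C(Nc2ccc(C(F)(F)F)cc2)C(=O)c2c1nc1n2[C@H]2OC[C@@H](O)[C@H]2OC1`: 2820 nM
compound 3 `CCCc1ccc(NC2=CC(=O)c3nc4n(c3C2=O)[C@H]2OC[C@@H](O)[C@H]2OC4)cc1`: 1560 nM

Compound 1 gives the lowest of the three numbers in this assay; compound 3 sits within the scatter of it, while compound 2 lies beyond it, a 2.2-fold higher number from compound 1 to compound 2 (0.34 log units; beyond the scatter). Compound 4 `O=C1C=C(N2CCCCC2)C(=O)c2c1nc1n2[C@H]2OC[C@@H](O)[C@H]2OC1` is compound 1 with piperidin-1-yl in place of (4-ethylphenyl)amino on a double-bonded ring carbon. Among the measured compounds shown here, none of the measured steps touches this position: a 1.2-fold higher number from compound 1 to compound 3 (0.08 log units; within the scatter) and a 1.8-fold lower number from compound 2 to compound 3 (0.26 log units; within the scatter) only vary the group on the aromatic ring that now leaves. The aromatic ring and the hydrogen-bond donor are both lost, a larger change than any measured here, so compound 4 is expected to give a higher number, a 3.5-fold higher number from compound 1 to compound 4 (0.54 log units; beyond the scatter). Compound 4 is thus estimated at 4500 nM, within 1200 nM to 17000 nM.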

Compound 4, half-maximal inhibitory concentration: > 8000 nM
Compound 4 was reported as a limit; the forecaster's own chance of this, stated with the estimate: 10%; at least 1.7-fold (0.24 log units) between middle value and limit.
By their numbers in this assay, from the lowest: compounds 1, 3 and 2 (each within the scatter of the next, the first and the last beyond it). At a limit, above all of these: compound 4.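

In this assay compound 4 gives > 8000 nM, which is a limit of the assay and not a number. Piperidin-1-yl in place of (4-ethylphenyl)amino gives an at least 6.2-fold higher number from compound 1 to compound 4 (0.79 log units; beyond the scatter), a larger step than any among the aromatic-ring variations of compound 1, compound 2 and compound 3, so this position responds more strongly than those variations showed. The full size of the step stays unknown: the limit of > 8000 nM in this assay, at which 1 of the 4 values shown sits.

The aromatic ring and the hydrogen-bond donor leave together, so the compounds shown cannot separate them. Going by these compounds, how a cyclohexylamino or a methyl(phenyl)amino group on this carbon would read remains open.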